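The source may report more compounds than this note shows. Statements on the series, on what has been measured and on what is new or still open speak of the compounds shown alone.

Compound 1, `CN(C)c1cc(OCc2cc(F)c(Oc3ccc(Cl)c(C(F)(F)F)c3)c(F)c2)nc(=O)n1C`, gives 0.65 10^-6 cm/s in an ADME assay on Caco-2 cells (Homo sapiens) for permeability, read by LC-MS, in the apical to basolateral direction, with a stated time of 95 min; a higher number here means that the compound crosses the layer faster, a lower number that the compound crosses the layer more slowly.
Compound 2, `CCOC(=O)CN(C)c1cc(OCc2cc(F)c(Oc3ccc(Cl)c(C(F)(F)F)c3)c(F)c2)nc(=O)n1C`, gives 0.32 10^-6 cm/s in this assay.
Compound 3, `Cn1c(N2CCCCC2)cc(OCc2cc(F)c(Oc3ccc(Cl)c(C(F)(F)F)c3)c(F)c2)nc1=O`, gives 0.01 10^-6 cm/s in this assay.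

Compound 3 stands lowest of the three numbers: a 32-fold lower number from compound 2 to compound 3 (1.51 log units; beyond the scatter) and a 65-fold lower number from compound 1 to compound 3 (1.81 log units; beyond the scatter), both beyond the scatter, whereas a 2.0-fold lower number from compound 1 to compound 2 (0.31 log units; beyond the scatter) is only modest. Compound 4, `Cn1c(N2CCN(C3CC3)CC2)cc(OCc2cc(F)c(Oc3ccc(Cl)c(C(F)(F)F)c3)c(F)c2)nc1=O`, has not yet been measured in this assay. It differs from compound 3 in one place: 4-cyclopropylpiperazin-1-yl in place of piperidin-1-yl on an aromatic carbon. Going by the values given here, none of the measured steps carries this change; the two large steps into compound 3 both swap an open-chain amino group for the ring, and the modest step between compound 1 and compound 2 alters a chain on the nitrogen. No step exchanges one ring for another at this position, so the direction of a 3.0-fold higher number from compound 3 to compound 4 (0.48 log units; beyond the scatter) cannot be read from a matching precedent and is expected to be small, with compound 3 already at the bottom of the numbers shown. Compound 4 is therefore estimated at 0.03 10^-6 cm/s in this assay, within 0.005 10^-6 cm/s to 0.2 10^-6 cm/s.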

Compound 4, apparent permeability: 0.43 10^-6 cm/s
Beside the measured number, compound 4's estimate is 14-fold (1.16 log units) below it, outside the stated range (above it).
By their numbers in this assay, from the lowest: compound 3; then compounds 2, 4 and 1 (each within the scatter of the next, the first and the last beyond it).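

Changing one ring for another at this position is not a neutral exchange in this assay: 4-cyclopropylpiperazin-1-yl in place of piperidin-1-yl gives a 43-fold higher number from compound 3 to compound 4 (1.63 log units; beyond the scatter) and so shows that the low number of compound 3 does not extend to every ring placed here. Going by these compounds alone, an open-chain amino group is also not required to reach the level of the earlier compounds, with a 1.3-fold higher number from compound 2 to compound 4 (0.13 log units; within the scatter) and a 1.5-fold lower number from compound 1 to compound 4 (0.18 log units; within the scatter) both staying within the scatter. Nothing measured here explains why the two rings differ so widely.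

The step brings in a second ring nitrogen and a cyclopropyl ring together, and the compounds shown do not separate the two. Piperazin-1-yl without the cyclopropyl ring, 4-methylpiperazin-1-yl or morpholin-4-yl at this position could tell these parts apart.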